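The compounds below may be only part of what the source reports. "The series", "measured", "known", "first", "only" and "open" are said of these compounds alone.

Among the measured compounds shown here, in a functional assay on MOLT-4 cells (Homo sapiens) for inhibition (on this read-out lower numbers stand for stronger inhibition and higher numbers for weaker inhibition), three compounds have numbers so far. Compound 1 `O=C1/C(=C/c2ccc(F)cc2)CCCc2ccccc21` gives 53600 nM, compound 2 `O=C1CCCCC/C1=C\c1ccccc1` gives 215000 nM, and compound 3 `O=C1CCCCC/C1=C\c1cccc(F)c1` gives 482000 nM. Compound 3 therefore holds the highest number of the three and is the weakest inhibitor among them, with its gaps to both others lying beyond the scatter.

The next compound, compound 4 `O=C1CCCCC/C1=C\c1cccc(Cl)c1`, keeps the core of compound 3 and alters a single substituent: chloro in place of fluoro on an aromatic carbon.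

For the measured compounds named here, only one measured step bears on this change: a 2.2-fold higher number from compound 2 to compound 3 (0.35 log units; beyond the scatter), a modest move seen when fluoro replaced hydrogen on an aromatic carbon. Going by the values given here, no measured pair exchanges one halogen for another, and compound 1 differs from the other two in more than one place, so it gives no direct guide. With so little evidence, the change in this assay is expected to be small, slightly toward a lower number and not clearly beyond the scatter. The expected change is a 1.4-fold lower number from compound 3 to compound 4 (0.14 log units; within the scatter). Compound 4 is estimated at 350000 nM, with an expected range from 150000 nM to 800000 nM.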

Compound 4, half-maximal inhibitory concentration: 88600 nM
Compound 4: middle estimate off by 4.0-fold (0.60 log units), on the high side; the whole stated range lies above it.
By their numbers in this assay, from the lowest: compounds 1 and 4 (each within the scatter of the next); then compound 2; then compound 3.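

In this assay the exchange of fluoro for chloro on this aromatic carbon gives a clear step (a 5.4-fold lower number from compound 3 to compound 4 (0.74 log units; beyond the scatter)), so the identity of the halogen at this place counts, and not merely whether a halogen is present. Measured against the unsubstituted compound 2, the two halogens move the number in opposite directions: fluoro gave a weaker result (a 2.2-fold higher number from compound 2 to compound 3 (0.35 log units; beyond the scatter)), while chloro gives a stronger one (a 2.4-fold lower number from compound 2 to compound 4 (0.39 log units; beyond the scatter)). A single substituent on this carbon, meta to a group of 9 heavy atoms, can therefore shift the number either way in this small set, which the fluoro step alone could not show, and no measurement offered here accounts for the difference between the two halogens.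

On these data alone, whether the trend would continue with bromo, or whether groups of another kind such as methoxy or an amine on the same carbon would favour stronger or weaker inhibition, remains open. As far as these compounds go, it also remains open whether the exchange of fluoro for chloro would have a similar effect on the core of compound 1.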